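The source may hold more compounds than are shown below. What is called first, only, known or untested is meant among the compounds shown, and "the series" means these compounds.

compound 1 `O=C1/C(=C\c2ccccc2)N=C(c2ccccc2)N1c1ccc2oc(-c3ccccc3)cc(=O)c2c1` 20.1 ug/mL
compound 2 `COc1ccc(/C=C2/N=C(c3ccccc3)N(c3ccc4oc(-c5ccccc5)cc(=O)c4c3)C2=O)cc1` 14.2 ug/mL
compound 3 `O=C1/C(=C\c2ccc(Cl)c(Cl)c2)N=C(c2ccccc2)N1c1ccc2oc(-c3ccccc3)cc(=O)c2c1` 15.2 ug/mL

In a functional assay on HeLa cells (Homo sapiens) for inhibition, read by MTT assay (a higher number here means a weaker inhibitor, a lower number a stronger inhibitor), compound 1 stands within the scatter of both other compounds, and the three values lie close together. Compound 4 `O=C1/C(=C\c2ccc(O)cc2)N=C(c2ccccc2)N1c1ccc2oc(-c3ccccc3)cc(=O)c2c1` has not yet been measured. It is compound 1 with a single change, (hydroxy in place of hydrogen on an aromatic carbon), which is hydroxy in place of hydrogen on an aromatic carbon, or phenyl to 4-hydroxyphenyl.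

Going by the values given here, three measured steps bear on this change. The closest in kind puts methoxy in place of hydrogen on an aromatic carbon, and it is a 1.4-fold lower number from compound 1 to compound 2 (0.15 log units; within the scatter). Replacing phenyl with 3,4-dichlorophenyl gives a 1.3-fold lower number from compound 1 to compound 3 (0.12 log units; within the scatter), and exchanging the two substituted rings gives a 1.1-fold higher number from compound 2 to compound 3 (0.03 log units; within the scatter). None of these steps leaves the scatter, so neither added group separates its compound from compound 1 in this assay. Among the compounds with values here, no compound with a hydroxy group has been measured, however, and three compounds make a thin basis.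

A small step is therefore expected, with no firm direction and nothing beyond the scatter. The expected step is a 1.3-fold lower number from compound 1 to compound 4 (0.10 log units; within the scatter). For compound 4 the estimated value is 16 ug/mL, with an expected range from 8 ug/mL to 30 ug/mL.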

Compound 4, half-maximal inhibitory concentration: 16.4 ug/mL
Compound 4: the middle estimate sits 1.0-fold (0.01 log units) below what was measured; measured number inside the range.
By their numbers in this assay, from the lowest: compounds 2, 3, 4 and 1 (each within the scatter of the next).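

In this assay, hydroxy carries a hydrogen-bond donor, yet on the aromatic carbon para to a large group it does not separate compound 4 from the unsubstituted phenyl of compound 1 (a 1.2-fold lower number from compound 1 to compound 4 (0.09 log units; within the scatter)). The result also isolates the methyl on the oxygen of compound 2: taking it away to leave hydroxy stays within the scatter (a 1.2-fold higher number from compound 2 to compound 4 (0.06 log units; within the scatter)), so this assay does not distinguish hydroxy from methoxy at this position. Exchanging the 3,4-dichlorophenyl ring for 4-hydroxyphenyl likewise stays within the scatter (a 1.1-fold higher number from compound 3 to compound 4 (0.03 log units; within the scatter)), so hydroxy, methoxy and the two chlorines all leave the number within the scatter of that of compound 1, and these four compounds give no sign of a trend at this ring.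

From the compounds shown here alone, it remains open whether an amine or a carboxylic acid on this ring, or a longer chain on the oxygen, would give a step beyond the scatter. No measurement among those shown offers a reason for how closely these numbers lie.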